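This account rests on a few compounds, and the source may have more. Where it says the series, first, only, none or still open, it means among the compounds named here.

Compound 1 `CCc1ccc(SCc2ccc(/C=C/C(=O)Nc3ccccc3N)cc2)cc1` gives 13.2% 
Compound 2 `Nc1ccccc1NC(=O)/C=C/c1ccc(CSc2ccc(C(F)(F)F)cn2)cc1` gives 12.1% 
Compound 3 `Nc1ccccc1NC(=O)/C=C/c1ccc(CSc2ccc(F)cc2)cc1` gives 18.3% 

In a functional assay on SMMC-7721 cells (Homo sapiens) for inhibition, read by CCK-8 assay, with a stated time of 72 h, tested at 2 uM (on this read-out higher numbers stand for more inhibition of growth at the one concentration tested and lower numbers for less inhibition of growth), compound 3 cannot be told apart from the other two compounds: a number 5.1 percentage points higher from compound 1 to compound 3 (within the scatter) and a number 6.2 percentage points higher from compound 2 to compound 3 (within the scatter) are both within the scatter. Compound 4 `CC(C)(C)c1ccc(SCc2ccc(/C=C/C(=O)Nc3ccccc3N)cc2)cc1` has tert-butyl in place of fluoro on an aromatic carbon, para to a large group (tert-butyl in place of fluoro on an aromatic carbon). The closest measured change is a number 5.1 percentage points higher from compound 1 to compound 3 (within the scatter). It swaps fluoro and ethyl on that same aromatic carbon. The change of the whole group on sulfur, a number 1.1 percentage points lower from compound 1 to compound 2 (within the scatter), is also within the scatter. Within the data shown here, no measured compound carries tert-butyl, so its effect remains untested. With such small steps across the series, no step beyond the scatter is expected in this assay. The expected step is a number 4.3 percentage points lower from compound 3 to compound 4 (within the scatter) and would remain within the scatter. Compound 4 is estimated at 14% in this read-out. The expected range for compound 4 runs from 4% to 26% in this read-out.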

Compound 4, percent growth inhibition at one concentration: 18.3%
Estimate against measurement, compound 4: 4.3 percentage points below; the range from low to high includes it.
By their numbers in this assay, from the lowest: compounds 2, 1, 3 and 4 (each within the scatter of the next).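

In this assay, the swap of fluoro for tert-butyl, which brings 4 heavy atoms in place of 1 on an aromatic carbon para to a large group, gives no change at the digits printed from compound 3 to compound 4 (within the scatter) and so adds no measurable difference. Tert-butyl in place of ethyl at that carbon gives a number 5.1 percentage points higher from compound 1 to compound 4 (within the scatter) and the exchange of the whole group on sulfur gives a number 6.2 percentage points higher from compound 2 to compound 4 (within the scatter) so that fluoro, ethyl and tert-butyl cannot be told apart here, nor can the 4-(tert-butyl)phenyl and 5-(trifluoromethyl)pyridin-2-yl groups on sulfur. No supporting evidence bears on why these compounds read alike.

The compounds shown leave open whether an amine or a carboxylic acid on that aromatic carbon would give a step beyond the scatter. They also leave open whether these groups would still read alike at other concentrations.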